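Swapping a halogenated phenyl on the piperazine nitrogen

This account rests on a few compounds, and the source may have more. Where it says the series, first, only, none or still open, it means among the compounds named here.

Compound 1 `Nc1ccccc1NC(=O)c1ccc(CSC(=S)N2CCN(c3ccc(Cl)cc3)CC2)cc1` and compound 2 `Nc1ccccc1NC(=O)c1ccc(CSC(=S)N2CCc3ccc([N+](=O)[O-])cc32)cc1` share a core and were tested in a functional assay on MGC-803 cells (Homo sapiens) for antiproliferative activity, read by CCK-8 assay, with a stated time of 72 h, tested at 8 uM; on this read-out lower numbers stand for a weaker effect and higher numbers for a stronger effect at the one concentration tested. Compound 1 gives 17.2%, the lowest of the two numbers, while compound 2 gives 39.6%, a gap beyond the scatter. Compound 3 `Nc1ccccc1NC(=O)c1ccc(CSC(=S)N2CCN(c3ccccc3F)CC2)cc1` has not been measured. It differs from compound 1 in one place: 2-fluorophenyl in place of 4-chlorophenyl on an amine nitrogen in a ring. Going by the values given here, no step between measured compounds is available for this change, so the step of a number 1.2 percentage points lower from compound 1 to compound 3 (within the scatter) is expected to stay within the scatter, with no clear direction. Compound 3 is thus estimated at 16%, in a range from 5% to 30%.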

Compound 3, a percentage reported as inhibition, at one concentration (the size of the read-out at that concentration, not a potency): 86.4%
Compound 3: middle estimate off by 70.4 percentage points, on the low side, and the stated range ends below it.
By their numbers in this assay, from the lowest: compound 1; then compound 2; then compound 3.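

In this assay, 2-fluorophenyl in place of 4-chlorophenyl on the amine nitrogen in the ring gives a number 69.2 percentage points higher from compound 1 to compound 3 (beyond the scatter), so this position responds strongly to which halogenated phenyl it carries. The two groups match in heavy-atom count and in hydrogen-bond donors and acceptors, so those counts do not separate them. No measured evidence bears on why the step is so large. The compounds shown do not separate the halogen from its place on the phenyl, since both change in this one step, and they give no reading for a plain phenyl or a methoxyphenyl on that nitrogen.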